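Plasma half-life notes: from compound 2 to compound 4

The source may hold more compounds than are shown below. What is called first, only, known or untested is meant among the compounds shown, and "the series" means these compounds.

Measured in an ADME assay on a cell-free system (plasma, Mus musculus) for metabolic stability, read by LC-MS, tested at 2 uM; a higher number here means that the compound lasts longer, a lower number that the compound disappears faster:
- compound 1 `CC(C)CNC(=O)n1c(=O)oc2ccc(C3CCN(C)CC3)cc21` gives 0.5 h
- compound 2 `CC(=O)N1CCC(c2ccc3c(c2)oc(=O)n3C(=O)NCCCCc2ccccc2)CC1` gives 0.5 h
- compound 3 `CN1CCC(c2ccc3c(c2)oc(=O)n3C(=O)NCCCCc2ccc(F)cc2)CC1` gives 0.333 h

Compound 2 stands level with compound 1, and compound 3 lies within the scatter of both. Compound 4 `CCN1CCN(c2ccc3c(c2)oc(=O)n3C(=O)NCCCCc2ccccc2)CC1` is still unmeasured. It carries 4-ethylpiperazin-1-yl in place of the 1-acetylpiperidin-4-yl of compound 2 on an aromatic carbon (4-ethylpiperazin-1-yl in place of 1-acetylpiperidin-4-yl on an aromatic carbon). For the measured compounds named here, no measured pair isolates this change. Compound 3 at 0.333 h and compound 2 at 0.5 h differ in more than one place, yet remain within the scatter of each other. The expected change is no change at the digits printed from compound 2 to compound 4 (within the scatter), in neither direction beyond the scatter. For compound 4 the estimated half-life is 0.5 h, with an expected range from 0.25 h to 1.1 h.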

Compound 4, half-life: < 0.0834 h
Compound 4 ended at the assay's limit; the forecaster's own chance of this, stated with the estimate: 5%; at least 5.9-fold (0.77 log units) between middle value and limit.
By their numbers in this assay, from the lowest: compounds 3, 1 and 2 (each within the scatter of the next). At a limit, below all of these: compound 4.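

In this assay, 4-ethylpiperazin-1-yl in place of 1-acetylpiperidin-4-yl on an aromatic carbon gives an at least 5.9-fold lower number from compound 2 to compound 4 (0.77 log units; beyond the scatter). Compound 4 at < 0.0834 h is a limit of the assay and not a number. For the compounds shown here, no earlier pair isolated a change at this position, and this step shows that the group on this aromatic carbon can move the half-life beyond the scatter.

The step changes the ring and the group on its nitrogen together, so the part that carries it cannot be told. A 4-acetylpiperazin-1-yl or a 1-ethylpiperidin-4-yl group at this position would separate the two.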